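A Benzyl Group in Place of Hydrogen on a Charged Chain

The source may report more compounds than this note shows. Statements on the series, on what has been measured and on what is new or still open speak of the compounds shown alone.

Three compounds built on a shared core were measured in a physicochemical assay for solubility; on this read-out higher numbers stand for higher solubility and lower numbers for lower solubility. Compound 1 `COc1cc2cc(C(=O)C=C3CC[N+](C)(Cc4ccccc4)CC3)sc2cc1OC` gives 25000 ug/mL in this assay. Compound 2 `COc1cc2cc(C(=O)CCC3CC[N+](C)(Cc4ccc([N+](=O)[O-])o4)CC3)sc2cc1OC` gives 600 ug/mL. Compound 3 `COc1cc2cc(C(=O)CCc3cc[n+](C)cc3)sc2cc1OC` gives 3000 ug/mL, the second highest of the three numbers, well below compound 1 and well above compound 2, both gaps beyond the scatter.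

Compound 4 `COc1cc2cc(C(=O)CCc3cc[n+](Cc4ccccc4)cc3)sc2cc1OC` differs from compound 3 by phenyl in place of hydrogen on a saturated chain carbon bound to an aromatic nitrogen. Among the measured compounds shown here, no measured pair isolates this change: compound 1 carries a benzyl on its charged nitrogen and gives the highest number, compound 2 a different group there and the lowest, but each also differs elsewhere. The step of a 1.5-fold lower number from compound 3 to compound 4 (0.18 log units; within the scatter) is expected to be small, downward if anything. Compound 4 is estimated at 2000 ug/mL, within 400 ug/mL to 10000 ug/mL.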

Compound 4, solubility: 2000 ug/mL
Compound 4: the middle estimate sits on the measured number at the digits printed, within the range that was stated.
By their numbers in this assay, from the lowest: compound 2; then compounds 4 and 3 (each within the scatter of the next); then compound 1.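

Among the compounds shown here, compound 3 and compound 4 form the first measured pair that isolates phenyl in place of hydrogen on a saturated chain carbon bound to an aromatic nitrogen. In this assay the step of a 1.5-fold lower number from compound 3 to compound 4 (0.18 log units; within the scatter) lies within the scatter, so this pair shows no measurable difference for this change at this position. Nothing available explains this result.

Still open, as far as these compounds go, is whether another group at this position, such as an amine, a carboxylic acid on the phenyl or a longer chain ending in phenyl, would give a step beyond the scatter.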